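The source may hold more compounds than are shown below. What is called first, only, known or untested is meant among the compounds shown, and "the series" means these compounds.

Of the compounds shown here, three have so far been measured in a functional assay on HT-29 cells (Homo sapiens) for antiproliferative activity, read by MTT assay, with a stated time of 24 h; on this read-out higher numbers stand for weaker inhibition and lower numbers for stronger inhibition. Compound 1 `COc1cc(OC)c(OC)cc1/C=C/C(=O)c1ccc(OC)c2c1OC(C)(C)C=C2` returns only a limit in this assay, namely > 10000 nM. Compound 2 `COc1ccc(C(=O)/C=C/c2ccc(N(c3ccccc3)c3ccccc3)cc2)c2c1C=CC(C)(C)O2` likewise returns only a limit in this assay, namely > 10000 nM. Among the compounds with values here, compound 3 `COc1ccc(C(=O)/C=C/c2cccc(C(F)(F)F)c2)c2c1C=CC(C)(C)O2` is the one compound with a number: in this assay compound 3 gives 9050 nM. Within the data shown here, compound 3 therefore stands as the only number in the set, while the two other values sit at the limit of > 10000 nM in this assay, at which 2 of the 3 values shown sit.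

Compound 4 `COc1ccc(C(=O)/C=C/c2cccc(O)c2)c2c1C=CC(C)(C)O2` has not yet been measured. It differs from compound 3 in a single place: hydroxy in place of trifluoromethyl on an aromatic carbon. No step between two measured compounds is shown, so nothing measured bears directly on the size of this change in this assay. The expected step from compound 3 to compound 4 is a 1.0-fold lower number from compound 3 to compound 4 (0.00 log units; within the scatter), and it is expected to stay within the scatter rather than move in either direction beyond it. Compound 4 is accordingly estimated at 9000 nM in this assay, with a range from 3000 nM to 30000 nM.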

Compound 4, half-maximal inhibitory concentration: > 10000 nM
Compound 4 gave a limit, no number; the forecaster's own chance of this, stated with the estimate: 45%; middle value at least 1.1-fold (0.04 log units) from the limit.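

Within the data shown here, the change from trifluoromethyl to hydroxy on an aromatic carbon, meta to a large group, is the first single-place change that can be read in this assay, and it gives an at least 1.1-fold higher number from compound 3 to compound 4 (0.04 log units; that floor lies within the scatter). Only a floor of that step is fixed, so the result shows that hydroxy at this position does not bring a number within reach, but not how much is lost. Compound 4 returns only a limit, > 10000 nM, and so joins the compounds without a number: the limit of > 10000 nM in this assay, at which 3 of the 4 values shown sit.

The compounds shown leave open how far this step lies beyond its floor, and whether an amine or a nitrile on the same aromatic carbon would give a number at all in this assay. They also do not tell whether any group at this place could give a lower number than compound 3.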